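The compounds below may be only part of what the source reports. "The series", "measured", "known", "first", "only" and "open" are said of these compounds alone.

In an ADME assay on cells (Hepatocyte, Mus musculus) for cytotoxicity, read by MTT assay, with a stated time of 24 h (a lower number here means that less compound is tolerated, a higher number that more compound is tolerated), compound 2 `O=S(=O)(c1ccc(F)cc1)n1c(-c2cn(-c3ccccc3)nc2-c2ccc(C(F)(F)F)cc2)nc2ccccc21` gives 83300 nM and compound 1 `O=S(=O)(c1ccc(C(F)(F)F)cc1)n1c(-c2cn(-c3ccccc3)nc2-c2ccc(F)cc2)nc2ccccc21` gives 55300 nM in the same test, so these two values lie within the usual scatter of each other. Compound 3 `O=S(=O)(c1ccc(C(F)(F)F)cc1)n1c(-c2cn(-c3ccccc3)nc2-c2ccc(C(F)(F)F)cc2)nc2ccccc21` differs from compound 2 in one place, with trifluoromethyl in place of fluoro on an aromatic carbon, para to a large group: trifluoromethyl in place of fluoro on an aromatic carbon is the whole difference. Among the measured compounds shown here, no two measured compounds differ in just one place, so no measured step shows what such a swap does. For the measured compounds named here, the only guide is how close compound 2 at 83300 nM and compound 1 at 55300 nM lie to each other. A step no larger than the scatter is therefore expected, leaning slightly towards a lower number. The estimated move is a 1.4-fold lower number from compound 2 to compound 3 (0.14 log units; within the scatter) and it stays within the scatter. In this assay the estimate for compound 3 is 60000 nM with 30000 nM to 120000 nM as its expected range.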

Compound 3, half-maximal cytotoxic concentration: 137000 nM
Compound 3: middle estimate off by 2.3-fold (0.36 log units), on the low side; the whole stated range lies below it.
By their numbers in this assay, from the lowest: compounds 1, 2 and 3 (each within the scatter of the next, the first and the last beyond it).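

In this assay, the swap of fluoro for trifluoromethyl can now be read at two places on the shared core: one gives a 1.6-fold higher number from compound 2 to compound 3 (0.22 log units; within the scatter) and the other gives a 2.5-fold higher number from compound 1 to compound 3 (0.39 log units; beyond the scatter) as a modest step. Among these three compounds, then, putting trifluoromethyl in place of fluoro brings no lower number at either place, and compound 3, which carries trifluoromethyl at both, can be told apart from compound 1 but not from compound 2. Nothing measured here offers an explanation for these numbers.

Still open, going by these compounds, is whether the same holds for other groups at these places, such as a methoxy group, an amine or a carboxylic acid. A plain hydrogen there would also show how much either halogen-bearing group matters at all.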